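A few compounds are considered here, and "the series" means these few. Any claim that something is new, unique, unknown or untested is made for them only; others in the source may bear on it.

Measured in a functional assay on NCI-H460 cells (Homo sapiens) for antiproliferative activity, read by MTT assay, with a stated time of 48 h; on this read-out higher numbers stand for weaker inhibition and lower numbers for stronger inhibition:
- compound 1 `COc1cc(-c2cccc3nc(-c4ccc(F)cc4)oc23)cc(OC)c1OC`: 8700 nM
- compound 2 `COc1cc(-c2cccc3nc(-c4ccc(Br)cc4)oc23)cc(OC)c1OC`: > 25000 nM (a limit, not a number)
- compound 3 `COc1cc(-c2cccc3nc(-c4cccc(C)c4)oc23)cc(OC)c1OC`: > 25000 nM (a limit, not a number)

Compound 3 has no number in this assay, only the limit > 25000 nM. It shares that position with one other compound: the limit of > 25000 nM in this assay, at which 2 of the 3 values shown sit.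

Compound 4 `COc1cc(-c2nc3cccc(-c4cc(OC)c(OC)c(OC)c4)c3o2)ccc1O` carries 4-hydroxy-3-methoxyphenyl in place of 3-methylphenyl on an aromatic carbon of the five-membered aromatic ring with 1 nitrogen and 1 oxygen: 4-hydroxy-3-methoxyphenyl in place of 3-methylphenyl on an aromatic carbon.

Two measured steps change this same aryl group: an at least 2.8-fold higher number from compound 1 to compound 2 (0.45 log units; beyond the scatter) and an at least 2.8-fold higher number from compound 1 to compound 3 (0.45 log units; beyond the scatter). Both are known only as minimum sizes, and both end at a limit. The third, a step that the two limits leave unreadable from compound 2 to compound 3, gives no size. None of the three compounds has a hydroxy or methoxy group on this aryl group, so the steps give the range the group can span rather than the effect of the new substituents.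

Among the compounds with values here, the only true number is that of compound 1, 8700 nM, so a modest move toward that level is expected. There is a real chance that compound 4 also ends at a limit. The expected change is an at least 2.5-fold lower number from compound 3 to compound 4 (0.39 log units; beyond the scatter). For compound 4 the estimated value is 10000 nM, with an expected range of 2000 nM to 25000 nM.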

Compound 4, half-maximal inhibitory concentration: 2000 nM
For compound 4 the middle estimate is 5.0-fold (0.70 log units) above the measured one; the range from low to high includes it.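

At this aromatic carbon of the five-membered aromatic ring with 1 nitrogen and 1 oxygen, this assay now yields a step with a true number at both ends, a 4.4-fold lower number from compound 1 to compound 4 (0.64 log units; beyond the scatter), so the aryl group can be exchanged for 4-hydroxy-3-methoxyphenyl with a readable gain over the 4-fluorophenyl compound. Against the other two compounds the same exchange reads as an at least 12-fold lower number from compound 3 to compound 4 (1.09 log units; beyond the scatter) and as an at least 12-fold lower number from compound 2 to compound 4 (1.09 log units; beyond the scatter), both minimum sizes set by a limit and not by a number: the limit of > 25000 nM in this assay, at which 2 of the 4 values shown sit. With its steps to all three others beyond the scatter, compound 4 is the most potent of the four shown, and it is the only one with a hydroxy or methoxy group on this aryl group.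

The step between the two limit compounds cannot be read, and the hydroxy and methoxy groups enter together in compound 4, so the share of each stays unresolved. Also open, from the compounds shown here alone, is how 4-hydroxyphenyl or 3-methoxyphenyl alone would read at this carbon, and whether an amine or a carboxylic acid on this aryl group would hold the gain.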